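The source may report more compounds than this note shows. Statements on the series, on what has been measured and on what is new or still open speak of the compounds shown alone.

Measured so far:
compound 1, `CC(C(=O)N1CCN(c2ccc(Cl)cc2)CC1)N1C(=O)CCC1=O`: 100%
compound 2, `CC(C(=O)N1CCN(c2ccc(C(F)(F)F)cc2)CC1)N1C(=O)CCC1=O`: 25%

In a functional assay on the whole organism (strain Swiss) with Mus musculus as the target, in the maximal electroshock model, with a stated time of 0.5 h, at a dose of 300 mg/kg by the intraperitoneal route (a lower number here means a weaker effect, a higher number a stronger effect of the compound at the dose given), compound 1 gives 100% and compound 2 gives 25%. Among the compounds with values here, compound 2 thus stands at the lowest of the two numbers, with compound 1 as its only neighbour. Within the data shown here, the one measured step in this assay is a number 75 percentage points lower from compound 1 to compound 2 (beyond the scatter); it changes the substituent on the aromatic ring and leaves the chain untouched.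

Compound 3, `CCC(C(=O)N1CCN(c2ccc(C(F)(F)F)cc2)CC1)N1C(=O)CCC1=O`, differs from compound 2 by methyl in place of hydrogen on a saturated chain carbon, two bonds along the chain from an amide-type nitrogen in a ring and a carbonyl carbon. Among the measured compounds shown here, no measured pair shows this change at the chain, so the step on the aromatic ring gives no guidance on it, and the expectation rests on compound 2 alone. Compound 3 is therefore estimated close to its parent, at 30%, within a range from 0% to 70%. The step this estimate means, a number 5 percentage points higher from compound 2 to compound 3 (within the scatter), is expected to fall within the usual scatter of this assay.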

Compound 3, a percentage reported as activity, at one dose (the size of the read-out at that dose, not a potency): 0%
The estimate for compound 3 lay 30 percentage points above the measured number; measured number inside the range.
By their numbers in this assay, from the lowest: compound 3; then compound 2; then compound 1.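

In this assay, the saturated chain carbon two bonds along the chain from an amide-type nitrogen in a ring and a carbonyl carbon proves sensitive: methyl in place of hydrogen, which also reads as methyl to ethyl, gives a number 25 percentage points lower from compound 2 to compound 3 (beyond the scatter). Within the data shown here, the earlier step concerned only the aromatic substituent, so this is the first sign that the chain also bears on the read-out. With compound 2 at 25% and compound 3 at 0%, the read-out has no room left below compound 3, so the step may understate the loss. No measured evidence bears on the origin of this drop.

Open, on these data alone, is whether the same change costs as much with chloro on the ring, where compound 1 offers more room to fall. Also open, as far as these compounds go, is how a propyl group, a longer chain, or a phenyl group at this carbon would read in this assay.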